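Aryl pyrazole acylthioureas: methoxy at the distal phenyl

The source may report more compounds than this note shows. Statements on the series, on what has been measured and on what is new or still open speak of the compounds shown alone.

Measured so far:
compound 1 `Cc1ccc(NC(=S)NC(=O)c2cn(-c3ccccc3)nc2-c2ccc(C)cc2)cc1` — 3760 nM
compound 2 `COc1ccc(-c2nn(-c3ccccc3)cc2C(=O)NC(=S)Nc2ccc(F)cc2)cc1` — 3050 nM
compound 3 `Cc1ccc(NC(=S)NC(=O)c2cn(-c3ccccc3)nc2-c2ccccc2)cc1` — 3960 nM

In a functional assay on NCI-H460 cells (Homo sapiens) for inhibition, read by CCK-8 assay, with a stated time of 48 h (a higher number here means a weaker inhibitor, a lower number a stronger inhibitor), compound 3 gives the highest of the three numbers, though its gaps to compound 1 and compound 2 both lie within the scatter. Within the data shown here, the step of a 1.1-fold higher number from compound 1 to compound 3 (0.02 log units; within the scatter) is the only single change with a measurement, and it stays within the scatter. Compound 4 `COc1ccc(-c2nn(-c3ccccc3)cc2C(=O)NC(=S)Nc2ccc(C)cc2)cc1` arises from compound 3 by methoxy in place of hydrogen on an aromatic carbon. Compound 2 carries the same methoxy group but differs from compound 3 in a second place as well, so its value can only be read as a rough pointer. Among the measured compounds shown here, with no single-change step bearing on the methoxy, the expectation for compound 4 is no step beyond the scatter, a 1.2-fold lower number from compound 3 to compound 4 (0.07 log units; within the scatter). Compound 4 is thus estimated at 3400 nM, within 1800 nM to 6500 nM.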

Compound 4, half-maximal inhibitory concentration: 2880 nM
For compound 4 the middle estimate is 1.2-fold (0.07 log units) above the measured one; the range from low to high includes it.
By their numbers in this assay, from the lowest: compounds 4, 2, 1 and 3 (each within the scatter of the next).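

In this assay, the change phenyl to 4-methoxyphenyl now has a single-change reading (a 1.4-fold lower number from compound 3 to compound 4 (0.14 log units; within the scatter)), and methoxy in place of methyl on the same aromatic carbon adds a second (a 1.3-fold lower number from compound 1 to compound 4 (0.12 log units; within the scatter)), so hydrogen, methyl and methoxy at this position are not told apart. Methyl in place of fluoro on an aromatic carbon of the other aryl group also stays within the scatter (a 1.1-fold lower number from compound 2 to compound 4 (0.02 log units; within the scatter)). No supporting measurement accompanies these steps.

As far as these compounds go, whether an amine or a carboxylic acid at this carbon would move the number beyond the scatter remains open.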